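Fluoro for Methoxy on a Shared Core

A few compounds are considered here, and "the series" means these few. Any claim that something is new, unique, unknown or untested is made for them only; others in the source may bear on it.

compound 1 `COc1ccc(-c2nn(-c3ccccc3)cc2C(=O)NOCc2ccccc2F)cc1`: 6000 nM
compound 2 `COc1ccc(-c2nn(-c3ccccc3)cc2C(=O)NOCc2ccc(Cl)cc2Cl)cc1`: 2570 nM

In a functional assay on MCF7 cells (Homo sapiens) for antiproliferative activity, read by MTT assay, with a stated time of 48 h, in the presence of a further agent that is not named here (a lower number here means a stronger inhibitor of growth, a higher number a weaker inhibitor of growth), compound 1 gives 6000 nM, while compound 2 gives 2570 nM and so stands lowest of the two numbers. Going by the values given here, the only step measured is a 2.3-fold lower number from compound 1 to compound 2 (0.37 log units; beyond the scatter). Compound 3 `O=C(NOCc1ccc(Cl)cc1Cl)c1cn(-c2ccccc2)nc1-c1ccc(F)cc1` differs from compound 2 by fluoro in place of methoxy on an aromatic carbon. Among the compounds with values here, no measured step touches this position, so that step offers little guidance, and a change of no more than the scatter in this assay is expected, with a 1.2-fold higher number from compound 2 to compound 3 (0.07 log units; within the scatter) as the estimated step. Compound 3 is therefore estimated at 3000 nM, between 1200 nM and 7500 nM.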

Compound 3, concentration for 50% growth inhibition: 25300 nM
For compound 3 the middle estimate is 8.4-fold (0.93 log units) below the measured one; the whole stated range lies below it.
By their numbers in this assay, from the lowest: compound 2; then compound 1; then compound 3.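

In this assay, going by these compounds alone, replacing 4-methoxyphenyl with 4-fluorophenyl gives a 9.8-fold higher number from compound 2 to compound 3 (0.99 log units; beyond the scatter), a larger change than the only other measured step, a 2.3-fold lower number from compound 1 to compound 2 (0.37 log units; beyond the scatter). Within the data shown here, this position, which the earlier compounds left untouched, therefore has a clear bearing on growth inhibition, and of this pair, the methoxy compound gives the lower number. Nothing available offers a measured reason for this difference. Still open, on these data alone, is how an amine, a hydroxyl or an ethoxy group would read on this aromatic carbon, and whether the methoxy-to-fluoro step keeps its size with the 2-fluorophenyl group of compound 1.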